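This account rests on a few compounds, and the source may have more. Where it says the series, first, only, none or still open, it means among the compounds named here.

Three compounds of the series have a reading in a functional assay on isolated protein for inhibition of Glucose-dependent insulinotropic receptor (Rattus norvegicus), read by HTRF and cAMP accumulation; a higher number here means a larger maximal response, a lower number a smaller maximal response. Compound 1 `CCC1(OC(=O)N2CCC(Oc3ncnc(Oc4ccc(S(C)(=O)=O)nc4C)c3F)CC2)CC1` gives 83%, compound 2 `Cc1nc(S(C)(=O)=O)ccc1Oc1ncnc(OC2CCN(C(=O)SC(C)(C)C)CC2)c1F` gives 76%, and compound 3 `Cc1nc(S(C)(=O)=O)ccc1Oc1ncnc(OC2CCN(C(=O)SC3CC3)CC2)c1F` gives 80%. Compound 3 stands second highest of the three; its gaps to compound 1 and to compound 2 are both within the scatter, the latter seen as a number 4 percentage points higher from compound 2 to compound 3 (within the scatter). Among the measured compounds shown here, all variation so far sits on the carbonyl carbon: a number 7 percentage points lower from compound 1 to compound 2 (within the scatter) and a number 3 percentage points lower from compound 1 to compound 3 (within the scatter), neither beyond the scatter.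

Compound 4 `CCc1cnc(C(=O)N2CCC(Oc3ncnc(Oc4ccc(S(C)(=O)=O)nc4C)c3F)CC2)nc1` is not yet measured. It differs from compound 3 by a group of 8 heavy atoms (6 carbon, 2 nitrogen; one six-membered aromatic ring with 2 hetero atoms) in place of a group of 4 heavy atoms (3 carbon, 1 sulfur; one three-membered non-aromatic ring of carbon only), on a carbonyl carbon, on the carbonyl carbon whose other neighbours are an amide-type nitrogen in a ring. The two measured steps at that carbonyl carbon, from compound 1 to compound 2 and from compound 1 to compound 3, bear on it, and both stayed within the scatter. For the measured compounds named here, the entering 5-ethylpyrimidin-2-yl has no precedent among the measured compounds, and the exchange is larger than any made so far.

The maximal response of compound 4 in this assay is therefore expected to move no further than the scatter, a step of a number 1 percentage points lower from compound 3 to compound 4 (within the scatter). Compound 4 is estimated at 79%, with a range from 64% to 92%.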

Compound 4, largest response reached (reported as efficacy), in percent of the reference or control that the assay uses: 80%
Estimate against measurement, compound 4: 1 percentage points below; the range from low to high includes it.
By their numbers in this assay, from the lowest: compounds 2, 3, 4 and 1 (each within the scatter of the next).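

At the carbonyl carbon whose other neighbours are an amide-type nitrogen in a ring, 5-ethylpyrimidin-2-yl brings the only aromatic ring placed there among the four compounds, and in this assay the comparison with the cyclopropyl-bearing sulfur group reads no change at the digits printed from compound 3 to compound 4 (within the scatter) and the comparison with (tert-butyl)sulfanyl reads a number 4 percentage points higher from compound 2 to compound 4 (within the scatter) and the comparison with the group of compound 1 reads a number 3 percentage points lower from compound 1 to compound 4 (within the scatter) and so none of the three leaves the scatter. The place therefore tolerates, for maximal response in this assay, a six-membered aromatic ring with 2 hetero atoms and 8 heavy atoms, a larger group than any of the non-aromatic groups seen there before, so the reading does not separate these four compounds. No supporting data bear on why the reading holds across this exchange.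

Open, going by these compounds, is whether a primary amine or a carboxylic acid on the same carbonyl carbon, or a longer chain such as butyl in place of the ethyl on the pyrimidine, would take the reading beyond the scatter. Also open, on these data alone, is whether any change outside this carbonyl carbon would do so, since the rest of the shared core is constant across the four compounds.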